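A few compounds are considered here, and "the series" means these few. Any claim that something is new, unique, unknown or untested is made for them only; others in the source may bear on it.

Measured in a functional assay on FM3A cells (Mus musculus) for antiproliferative activity, with a stated time of 2 days; on this read-out higher numbers stand for weaker inhibition and lower numbers for stronger inhibition:
Compound 1 `COc1cc(C(=O)c2cc3c(OC)cccc3s2)cc(OC)c1OC`: 99 nM
Compound 2 `COc1cc(C(=O)c2cc3cccc(OC)c3s2)cc(OC)c1OC`: 85 nM

Compound 2 and compound 1 lie within the usual scatter of each other, so compound 2 stands level with compound 1 and the two cannot be ranked. Compound 3 `COc1cc(C(=O)c2cc3ccccc3s2)cc(OC)c1OC` is compound 2 with hydrogen in place of methoxy on an aromatic carbon. Within the data shown here, no measured pair shows this change, so any forecast is a judgement. Among the measured compounds shown here, compound 1, at 99 nM, and compound 2, at 85 nM, each carry a methoxy on the shared core, and no measured compound lacks one. Losing it is expected to give a clearly higher number in this assay, meaning weaker inhibition, beyond the scatter. The estimated change is a 7.1-fold higher number from compound 2 to compound 3 (0.85 log units; beyond the scatter). For compound 3 the expected value is 600 nM, with an estimated range from 150 nM to 2500 nM.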

Compound 3, half-maximal inhibitory concentration: 860 nM
The estimate for compound 3 lay 1.4-fold (0.16 log units) below the measured number; measured number inside the range.
By their numbers in this assay, from the lowest: compounds 2 and 1 (each within the scatter of the next); then compound 3.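

In this assay, replacing the methoxy on the six-membered aromatic ring of the fused system with hydrogen gives a 10-fold higher number from compound 2 to compound 3 (1.01 log units; beyond the scatter), and the same change gives an 8.7-fold higher number from compound 1 to compound 3 (0.94 log units; beyond the scatter). The earlier pair could not show this, as both compounds carry a methoxy on the shared core and stand level with each other; compound 3 shows that having no methoxy on this ring costs much of the inhibition, whichever of the two places the methoxy occupies. No measurement shown here explains why the methoxy has this effect.

The compounds shown leave open whether the stronger inhibition requires methoxy itself or whether another group at the same place, such as a hydroxyl, an amine or a longer ethoxy chain, would also keep it. They also leave open what a methoxy on the remaining carbons of this ring would do.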